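N-Methylation in a Second Pyrrolidine Ether Series

The source may hold more compounds than are shown below. What is called first, only, known or untested is meant among the compounds shown, and "the series" means these compounds.

In an assay for binding affinity to Neuronal acetylcholine receptor; alpha4/beta2 (Rattus norvegicus) (on this read-out lower numbers stand for stronger inhibition and higher numbers for weaker inhibition), compound 1 `Clc1ncc(OCC2CCCN2)cc1/C=C/c1cccnc1` gives 0.028 nM, compound 2 `CN1CCCC1COc1cnc(Cl)c(/C=C/c2cccnc2)c1` gives 0.088 nM, and compound 3 `Clc1ncc(OCC2CCCN2)cc1/C=C/c1ccccn1` gives 0.331 nM. The core of compound 3 differs from that of compound 1 by pyridin-2-yl in place of pyridin-3-yl on a double-bonded chain carbon bound to a double-bonded chain carbon, a change that brought a 12-fold higher number from compound 1 to compound 3 (1.07 log units; beyond the scatter). Compound 2 differs from compound 1 by methyl in place of hydrogen on an amine nitrogen in a ring, and that step read a 3.1-fold higher number from compound 1 to compound 2 (0.50 log units; beyond the scatter). Compound 4 `CN1CCCC1COc1cnc(Cl)c(/C=C/c2ccccn2)c1`, not yet measured, differs from compound 3 by methyl in place of hydrogen on an amine nitrogen in a ring, the same change made at the same place. Among the compounds with values here, on the core of compound 3, whose own value in this assay is 0.331 nM, this change is expected to give a step of about a 3.0-fold higher number from compound 3 to compound 4 (0.48 log units; beyond the scatter), resting on the one measured instance between compound 1 and compound 2. Compound 4 is therefore estimated at 1 nM, with a likely range from 0.4 nM to 2.5 nM.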

Compound 4, inhibition constant: 0.265 nM
For compound 4 the middle estimate is 3.8-fold (0.58 log units) above the measured one, and the stated range ends above it.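

In this assay, methyl in place of hydrogen on an amine nitrogen in a ring gave a 1.2-fold lower number from compound 3 to compound 4 (0.10 log units; within the scatter), so the step seen on the core of compound 1 did not carry over to the core of compound 3: the same change on two cores in this assay, a 3.1-fold higher number (0.50 log units; beyond the scatter) from compound 1 to compound 2 and a 1.2-fold lower number (0.10 log units; within the scatter) from compound 3 to compound 4, 3.9-fold (0.59 log units) apart, beyond the scatter of two such steps. Pyridin-2-yl in place of pyridin-3-yl gave a 3.0-fold higher number from compound 2 to compound 4 (0.48 log units; beyond the scatter) on the methylated compounds, so the size of that step also depended on the core: the same change on two cores in this assay, a 12-fold higher number (1.07 log units; beyond the scatter) from compound 1 to compound 3 and a 3.0-fold higher number (0.48 log units; beyond the scatter) from compound 2 to compound 4, 3.9-fold (0.59 log units) apart, beyond the scatter of two such steps. These four compounds show that the two changes do not add independently here, but they do not show why, or how either change would read on any other core.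

From the compounds shown here alone, it remains open whether an ethyl group or a longer chain on that amine nitrogen would follow compound 2 or compound 4.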